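A few compounds are considered here, and "the series" means these few. Any claim that something is new, unique, unknown or untested is made for them only; others in the source may bear on it.

Measured compounds in a functional assay on cells for antagonist activity at C-C chemokine receptor type 4 (Homo sapiens), read by fluorescence and calcium flux, with stated times of 2.5 s and 45 s; on this read-out higher numbers stand for weaker inhibition and lower numbers for stronger inhibition:
Compound 1 `CC(c1ccc(Cl)cc1Cl)n1ncc2ncc(N3CCC(N4CCCCC4)CC3)nc21` gives 2580 nM.
Compound 2 `Cc1nn([C@H](C)c2ccc(Cl)cc2Cl)c2nc(N3CC[C@@H](N4CCCCC4)[C@@H](C)C3)cnc12` gives 803 nM.
Compound 3 `Cc1nn(C(C)c2ccc(Cl)cc2Cl)c2nc(N3CCC(N4CCCCC4)C(C)C3)cnc12` gives 126 nM.

Compound 3 has the lowest number of the three. For the measured compounds named here, the only single-point step among them runs a 6.4-fold lower number from compound 2 to compound 3 (0.80 log units; beyond the scatter); the two compounds share every atom and bond, and the difference is that compound 2 is drawn with defined configurations while compound 3 is not (the fact that one of compounds 2 and 3 is drawn with a defined configuration and the other without, at the place where they differ).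

Compound 4 `CC1CN(c2cnc3c(C(N)=O)nn(C(C)c4ccc(Cl)cc4Cl)c3n2)CCC1N1CCCCC1` is not yet measured. It differs from compound 3 in one place: carbamoyl in place of methyl on an aromatic carbon. Going by the values given here, no measured step here changes that group, so the stereochemical step from compound 2 to compound 3 gives no guide to the size or direction of this change. With nothing in the data to lean on, a modest shift in either direction is as likely as none.

Compound 4 is therefore estimated to lie near its parent, at 200 nM, within a broad range from 40 nM to 1000 nM, an expected step of a 1.6-fold higher number from compound 3 to compound 4 (0.20 log units; within the scatter).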

Compound 4, half-maximal inhibitory concentration: 228 nM
Compound 4: middle estimate off by 1.1-fold (0.06 log units), on the low side; low and high end bracket the measured number.
By their numbers in this assay, from the lowest: compounds 3 and 4 (each within the scatter of the next); then compound 2; then compound 1.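

In this assay, putting carbamoyl in place of methyl on this aromatic carbon of the five-membered ring gives a 1.8-fold higher number from compound 3 to compound 4 (0.26 log units; within the scatter), so the number does not readably move. This position therefore takes a larger group, one that brings a hydrogen-bond donor and a hydrogen-bond acceptor where methyl had neither, and the inhibition stays within the usual spread of repeat measurements. Nothing shown here explains why this swap leaves the number so little altered.

As far as these compounds go, whether a carboxylic acid, a nitrile or a longer chain such as ethyl would fare as carbamoyl does at this position remains open. Also open, from the compounds shown here alone, is how a form of compound 4 drawn with defined configurations would compare with the undefined compound 4.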